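Cyano in place of methyl at the benzyl ring

This account rests on a few compounds, and the source may have more. Where it says the series, first, only, none or still open, it means among the compounds named here.

Of the compounds shown here, two sharing one core have been tested in a functional assay on NIH3T3 cells (Mus musculus) (on this read-out lower numbers stand for an effect already at smaller amounts and higher numbers for an effect only at larger amounts of compound), so far. Compound 1 `N#Cc1ccc(Cn2cncc2CNc2ccc(C(=O)NCc3ccccc3)c(-c3ccccc3)c2)cc1` already carries the 4-cyanobenzyl group; in this assay compound 1 gives only a limit, > 10 uM. Compound 2 `CSCC[C@H](NC(=O)c1ccc(NCc2cncn2Cc2ccc(C)cc2)cc1-c1ccccc1)C(=O)O` carries the 4-methylbenzyl group instead and differs from compound 1 at a second place as well; in this assay compound 2 also gives only a limit, > 10 uM. Compound 2 thus stands exactly where every result so far stands: the limit of > 10 uM in this assay, at which 2 of the 2 values shown sit. Compounds 1 and 2 differ in more than one place. Among the compounds with values here, no single step between measured compounds can be read from them, and their two values show only that both are limits.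

Compound 3 `CSCC[C@H](NC(=O)c1ccc(NCc2cncn2Cc2ccc(C#N)cc2)cc1-c1ccccc1)C(=O)O` arises from compound 2 by one change, (cyano in place of methyl on an aromatic carbon), cyano in place of methyl on an aromatic carbon of a six-membered aromatic ring of carbon only. With both measured compounds at the limit, the expected step from compound 2 to compound 3 is none beyond the scatter, a step that the limit leaves unreadable from compound 2 to compound 3. Compound 3 is therefore estimated at 15 uM, within 3 uM to 60 uM, and most probably reported again only as a limit.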

Compound 3, concentration for half-maximal effect: > 10 uM
Compound 3: a limit, no number (the forecaster's own chance of this, stated with the estimate: 75%); the middle value does not contradict the limit.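

Compound 3 ends up with the same result as compound 1 and compound 2, so no step can be read from compound 2 to compound 3 or from compound 1 to compound 3 in this assay: the limit of > 10 uM in this assay, at which 3 of the 3 values shown sit. The compounds shown leave open whether cyano in place of methyl, or 1-carboxy-3-(methylsulfanyl)propyl in place of benzyl, changes the effect at all.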